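The compounds below may be only part of what the source reports. "The series", "measured", "known", "first", "only" and "open" are said of these compounds alone.

Three analogues sharing one core have been tested in a functional assay on CHO-K1 cells for antagonist activity at melanin-concentrating hormone receptor 1 (Homo sapiens), read by inositol phosphate accumulation, with stated times of 10 min and 45 min; a lower number here means a stronger inhibitor, a higher number a weaker inhibitor. Compound 1 `Cc1nc(N2CCC(N3C(=O)CCC3=O)CC2)nc2ccc(NC(=O)/C=C/c3ccc(OC(F)(F)F)cc3)cc12` gives 35 nM. Compound 2 `Cc1nc(NCCNS(C)(=O)=O)nc2ccc(NC(=O)/C=C/c3ccc(OC(F)(F)F)cc3)cc12` gives 142 nM. Compound 3 `Cc1nc(N2CCC(N3CCOC3=O)CC2)nc2ccc(NC(=O)/C=C/c3ccc(OC(F)(F)F)cc3)cc12` gives 31 nM, the lowest of the three numbers, though its step from compound 1 is a 1.1-fold lower number from compound 1 to compound 3 (0.05 log units; within the scatter), and only its step from compound 2, a 4.6-fold lower number from compound 2 to compound 3 (0.66 log units; beyond the scatter), lies beyond the scatter.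

The next compound, compound 4 `Cc1nc(N2CCC(NS(=O)(=O)N(C)C)CC2)nc2ccc(NC(=O)/C=C/c3ccc(OC(F)(F)F)cc3)cc12`, departs from compound 3 in one place: (dimethylsulfamoyl)amino in place of 2-oxo-1,3-oxazolidin-3-yl on a saturated ring carbon. The step that bears most directly on it is the earlier swap at the same saturated ring carbon, a 1.1-fold lower number from compound 1 to compound 3 (0.05 log units; within the scatter), where exchanging one five-membered group for another left the number essentially unchanged. Among the compounds with values here, compound 2 also carries a sulfonamide-type group, but attached through an open chain at the aromatic carbon rather than at the saturated ring carbon, so its value speaks only loosely to compound 4; no step between compound 2 and compound 4 is available.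

On that basis compound 4 is expected to sit close to compound 3, with a step of a 1.2-fold higher number from compound 3 to compound 4 (0.09 log units; within the scatter) that should stay within the scatter. The estimate for compound 4 in this assay is 38 nM, with a range from 15 nM to 95 nM.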

Compound 4, half-maximal inhibitory concentration: 31 nM
Estimate against measurement, compound 4: 1.2-fold (0.09 log units) above; the range from low to high includes it.
By their numbers in this assay, from the lowest: compounds 3, 4 and 1 (each within the scatter of the next); then compound 2.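

At the saturated ring carbon, three ring bonds from the ring nitrogen, this assay gives no separation between the ringless (dimethylsulfamoyl)amino group and 2-oxo-1,3-oxazolidin-3-yl (no change at the digits printed from compound 3 to compound 4 (within the scatter)) or 2,5-dioxopyrrolidin-1-yl (a 1.1-fold lower number from compound 1 to compound 4 (0.05 log units; within the scatter)). Within the data shown here, the earlier step at this carbon exchanged only one five-membered non-aromatic ring for another, whereas this change removes the ring, brings in sulfur and offers 1 hydrogen-bond donor in place of 0, and still the number stays within the scatter among compounds 1, 3 and 4. No measurement at hand accounts for this lack of separation, so the result records what the position accepts and not why.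

The compounds shown leave open whether a basic amine, a carboxylic acid or a longer alkyl chain at the same saturated ring carbon would keep the number in this range. They also leave open what the amino hydrogen of compound 4 contributes, a question that a methyl group on that nitrogen would address directly.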